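A few compounds are considered here, and "the series" means these few. Any claim that something is new, unique, unknown or untested is made for them only; others in the source may bear on it.

Measured so far:
- compound 1, `Cn1nnnc1SCC(=O)Nc1ccc(-c2nc(-c3ccccc3)c(-c3ccccc3)n2C)cc1`: 84%
- compound 2, `Cc1nnc(SCC(=O)Nc2ccc(-c3nc(-c4ccccc4)c(-c4ccccc4)n3C)cc2)s1`: 87.1%
- compound 3, `CN1CCN(CC(=O)Nc2ccc(-c3nc(-c4ccccc4)c(-c4ccccc4)n3C)cc2)CC1`: 49.1%

All three were tested in a functional assay on HT-29 cells (Homo sapiens) for cytotoxicity, read by MTT assay, with a stated time of 24 h, tested at 32 ug/mL; on this read-out higher numbers stand for a stronger effect at the one concentration tested and lower numbers for a weaker effect. In this assay compound 3 gives the lowest number of the three. The steps of a number 34.9 percentage points lower from compound 1 to compound 3 (beyond the scatter) and a number 38 percentage points lower from compound 2 to compound 3 (beyond the scatter) are both large and beyond the scatter, so compound 3 is clearly the weakest of the measured set. The step of a number 3.1 percentage points higher from compound 1 to compound 2 (within the scatter) is within the scatter.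

Compound 4, `CCN1CCN(CC(=O)Nc2ccc(-c3nc(-c4ccccc4)c(-c4ccccc4)n3C)cc2)CC1`, differs from compound 3 by methyl in place of hydrogen on a saturated chain carbon bound to an amine nitrogen in a ring. Among the measured compounds shown here, none of the measured steps bears on such a change: the two large steps replace a whole sulfur-linked ring group with the piperazine ring, and the small step swaps one such ring for another. For the measured compounds named here, no measured pair compares a methyl with a hydrogen on a saturated chain carbon bound to an amine nitrogen in a ring. With nothing to suggest a shift, the expectation for compound 4 is a step within the scatter, a number 0.9 percentage points higher from compound 3 to compound 4 (within the scatter). Compound 4 is therefore estimated at 50%, with a range from 32% to 68%.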

Compound 4, a percentage reported as activity, at one concentration (the size of the read-out at that concentration, not a potency): 38.8%
The estimate for compound 4 lay 11.2 percentage points above the measured number; the range from low to high includes it.
By their numbers in this assay, from the lowest: compound 4; then compound 3; then compounds 1 and 2 (each within the scatter of the next).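

In this assay, the group carried by the piperazine ring matters: methyl in place of hydrogen on a saturated chain carbon bound to an amine nitrogen in a ring gives a number 10.3 percentage points lower from compound 3 to compound 4 (beyond the scatter), a modest step but one that a single added carbon produces on its own. Against the sulfur-linked ring groups, the 4-ethylpiperazin-1-yl group gives a number 48.3 percentage points lower from compound 2 to compound 4 (beyond the scatter) and a number 45.2 percentage points lower from compound 1 to compound 4 (beyond the scatter), which makes compound 4 the weakest of the four. No measurement here explains why the longer group lowers the number.

Going by these compounds, it remains open whether a longer chain such as propyl would lower the number further, or whether the trend extends to a piperazin-1-yl ring with only hydrogen on that nitrogen. A morpholin-4-yl ring in the same place would show whether the piperazine ring itself is needed.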